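A methoxy added on a chain carbon: toxicity outlook

The compounds below may be only part of what the source reports. "The series", "measured", "known", "first", "only" and "open" are said of these compounds alone.

Compound 1 `COc1nc2ccccc2cc1/C=C/c1noc(-c2ccc(F)cc2)n1` in an ADME assay on HepG2 cells (Homo sapiens) for cytotoxicity, read by sulforhodamine B assay, with a stated time of 48 h (on this read-out higher numbers stand for lower toxicity in this test and lower numbers for higher toxicity in this test), gives > 230000 nM, which is a limit of the test rather than a number.
Compound 2 `COc1ccccc1-c1nc(/C=C/c2cc3ccccc3nc2OC)no1` in this assay gives > 220000 nM, again a limit.
Compound 3 `COc1nc2ccccc2cc1/C=C/c1noc(C)n1` in this assay gives > 300000 nM, also a limit.

Among the measured compounds shown here, compound 3 thus stands at a limit, and the two further values shown are limits as well, so no compound here has a measured number. The steps a step that the two limits leave unreadable from compound 1 to compound 2, a step that the two limits leave unreadable from compound 1 to compound 3 and a step that the two limits leave unreadable from compound 2 to compound 3 each join two limits, and their size cannot be read.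

Compound 4 `COCc1nc(/C=C/c2cc3ccccc3nc2OC)no1` differs from compound 3 by methoxy in place of hydrogen on a saturated chain carbon bound to an aromatic carbon. For the measured compounds named here, none of the measured steps touches this part of the molecule; they vary the group on the other end of the shared core, and each was unreadable. Going by the values given here, the only footing is that compound 3 sits at a limit. The step of a number no higher from compound 3 to compound 4 (the limit leaves the size open) is therefore expected to be none beyond the scatter. For compound 4 the expected value in this assay is 300000 nM. For compound 4 the estimated range runs from 100000 nM to 1000000 nM, most likely reported again only as a limit.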

Compound 4, half-maximal cytotoxic concentration: > 270000 nM
Compound 4: only a limit was reported; the forecaster's own chance of this, stated with the estimate: 80%; the middle value does not contradict the limit.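

Among the compounds shown here, compound 4 also stands at a limit, so its steps from compound 1, compound 2 and compound 3 cannot be read, and no new step comes from it. With all four compounds at limits, the compounds shown leave open what concentration, if any, would harm these cells in this assay.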